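This account rests on a few compounds, and the source may have more. Where it says the series, first, only, none or still open, it means among the compounds named here.

In a functional assay on A549 cells (Homo sapiens) for inhibition, read by sulforhodamine B assay, with a stated time of 48 h (on this read-out higher numbers stand for weaker inhibition of growth and lower numbers for stronger inhibition of growth), compound 1 (`NC(=O)c1cc(Br)ccc1NC(=O)/C=C/c1ccccc1`) gives 1020 nM and compound 2 (`NC(=O)c1cc(I)ccc1NC(=O)/C=C/c1ccccc1`) gives 2650 nM as the higher of the two numbers. Compound 3 (`NC(=O)c1cc(I)ccc1NC(=O)/C=C/c1ccccc1Cl`) differs from compound 2 by chloro in place of hydrogen on an aromatic carbon, phenyl to 2-chlorophenyl (chloro in place of hydrogen on an aromatic carbon). Going by the values given here, the only measured step, iodo in place of bromo, is modest (a 2.6-fold higher number from compound 1 to compound 2 (0.41 log units; beyond the scatter)). It concerns a different change, so it offers a rough size and no direction. Only a modest step is therefore expected, estimated as a 1.2-fold lower number from compound 2 to compound 3 (0.06 log units; within the scatter) with no firm direction. In this assay the estimated value for compound 3 is 2300 nM within an expected range of 800 nM to 7000 nM as the likely span.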

Compound 3, concentration for 50% growth inhibition: 1870 nM
Compound 3: the middle estimate sits 1.2-fold (0.09 log units) above what was measured; low and high end bracket the measured number.
By their numbers in this assay, from the lowest: compounds 1, 3 and 2 (each within the scatter of the next, the first and the last beyond it).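

Turning phenyl to 2-chlorophenyl gives a 1.4-fold lower number from compound 2 to compound 3 (0.15 log units; within the scatter) in this assay, so a single chlorine on this aromatic carbon, ortho to a large group, leaves the growth-inhibition number indistinguishable from that of compound 2. This is the first change shown at this end of the molecule, and here it is a change the read-out cannot separate from repeat-measurement noise. No measurement is available to explain this result. Still open, on these data alone, is whether an amine or a methoxy group here would shift the number beyond the scatter, and whether chloro behaves alike with bromo in place of iodo, as in compound 1.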